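Three analogues on one core and a fourth awaiting its number

The source may hold more compounds than are shown below. What is called first, only, known or untested is meant among the compounds shown, and "the series" means these compounds.

Three compounds sharing a common core were tested in a functional assay on A549 cells (Homo sapiens) for antiproliferative activity, read by MTT assay, with a stated time of 72 h; a higher number here means a weaker inhibitor, a lower number a stronger inhibitor. Compound 1, with structure `CN(C(=O)c1ccc(Br)cc1)c1ccc2[nH]c(-c3n[nH]c4ccccc34)cc2n1`, gives 4250 nM. Compound 2, with structure `CN(C(=O)c1ccccc1)c1ccc2[nH]c(-c3n[nH]c4cc(C#N)ccc34)cc2n1`, gives 32800 nM in this assay. Compound 3, with structure `COc1ccc(S(=O)(=O)N(C)c2ccc3[nH]c(-c4n[nH]c5ccccc45)cc3n2)c(OC)c1`, gives 25900 nM in this assay. Among these three, compound 1 has the lowest number; the gap from compound 1 to compound 3 and the gap from compound 1 to compound 2 both lie beyond the usual scatter of repeated measurements, so compound 1 is the strongest inhibitor of the three in this assay.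

Compound 4, with structure `CN(C(=O)Nc1ccccc1)c1ccc2[nH]c(-c3n[nH]c4ccccc34)cc2n1`, has not yet been measured in this assay. It differs from compound 1 in one place: anilino in place of 4-bromophenyl on a carbonyl carbon. The amide of compound 1 thereby becomes a urea in compound 4, with one hydrogen-bond donor gained where none stood before.

Going by the values given here, no pair of measured compounds differing in just one place is available to show how such a change moves the number, so the expectation rests on compound 1 alone and on the width of the scatter. A moderate weakening is expected, a step of a 1.6-fold higher number from compound 1 to compound 4 (0.22 log units; within the scatter), though a result within the scatter of compound 1 would not surprise. Compound 4 is therefore expected to give about 7000 nM in this assay, most likely between 1800 nM and 28000 nM.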

Compound 4, half-maximal inhibitory concentration: 1430 nM
Beside the measured number, compound 4's estimate is 4.9-fold (0.69 log units) above it; the whole stated range lies above it.
By their numbers in this assay, from the lowest: compound 4; then compound 1; then compounds 3 and 2 (each within the scatter of the next).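

Replacing 4-bromophenyl with anilino on a carbonyl carbon gives a 3.0-fold lower number from compound 1 to compound 4 (0.47 log units; beyond the scatter) in this assay, so this position responds to change, and turning the amide into a urea, which adds a hydrogen-bond donor, does not cost activity here. Going by these compounds alone, this is the first direct reading of a single change in the set, as the earlier compounds differ from one another in more than one place and could only be set side by side. No measurement shown here explains why the number falls.

The step swaps the bromine-bearing ring for an unsubstituted one and adds the urea nitrogen with its hydrogen at the same time, so this single pair cannot separate those two changes. A 4-bromoanilino group would help to separate them, while a benzylamino group, with a longer chain, or a phenoxy group, with oxygen in place of the urea nitrogen, would show how much this position depends on that nitrogen and its hydrogen.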